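The source may hold more compounds than are shown below. What is called first, only, known or untested is meant among the compounds shown, and "the series" means these compounds.

Measured in a functional assay on DLD-1 cells (Homo sapiens) for cytotoxicity, read by MTT assay, with a stated time of 48 h; on this read-out lower numbers stand for stronger inhibition and higher numbers for weaker inhibition:
Compound 1, `CC(C)COc1ccc2c(Cl)ccnc2c1`: 3100 nM
Compound 2, `CCCCCCCCOc1ccc2c(Cl)ccnc2c1`: 4500 nM
Compound 3, `CN(C)CCNc1ccnc2cc(OCc3ccccc3)ccc12`: 2140 nM

Compound 2 holds the highest of the three numbers; compound 1 sits within the scatter of it, and only compound 3, with the lower number, stands beyond the scatter. Compound 4, `CCOc1ccc2c(Cl)ccnc2c1`, is not yet measured in this assay. It differs from compound 2 by hydrogen in place of hexyl on a saturated chain carbon, two bonds along the chain from an oxygen on an aromatic ring. Compound 1 and compound 2 carry the same core and differ only in the chain on the oxygen, yet their numbers lie within the scatter of each other, so chain length has shown no clear effect in this set. No step beyond the scatter is expected in either direction, and the estimated step is a 1.3-fold lower number from compound 2 to compound 4 (0.11 log units; within the scatter). Compound 4 is expected at 3500 nM, within 1500 nM to 8000 nM.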

Compound 4, half-maximal inhibitory concentration: 2750 nM
Estimate against measurement, compound 4: 1.3-fold (0.10 log units) above; measured number inside the range.
By their numbers in this assay, from the lowest: compounds 3, 4, 1 and 2 (each within the scatter of the next, the first and the last beyond it).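

Shortening the chain on the oxygen of the shared core gives no step beyond the scatter in this assay: hydrogen in place of hexyl gives a 1.6-fold lower number from compound 2 to compound 4 (0.21 log units; within the scatter), and methyl in place of isopropyl gives a 1.1-fold lower number from compound 1 to compound 4 (0.05 log units; within the scatter). Compound 1, compound 2 and compound 4 therefore show no clear dependence on this chain across the three chains tested. Nothing available explains why these numbers stay so close. Still open, as far as these compounds go, is whether an amine or a carboxylic acid in place of hexyl would give a step beyond the scatter.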